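Trading a Benzofuran for an Ethynyl on a Nucleoside

This account rests on a few compounds, and the source may have more. Where it says the series, first, only, none or still open, it means among the compounds named here.

Compound 1 `COc1nc(N)nc2c1c(-c1cc3ccccc3o1)cn2[C@@H]1O[C@H](CO)[C@@H](O)[C@H]1O` gives only a limit in a functional assay on A549 cells (Homo sapiens), read by MTT assay, with a stated time of 72 h; on this read-out higher numbers stand for weaker inhibition and lower numbers for stronger inhibition: its value there, > 20000 nM, is the boundary of what this assay reports, as the limit of > 20000 nM in this assay, at which 1 of the 2 values shown sits, records. Compound 2 `COc1ncnc2c1c(-c1cc3ccccc3o1)cn2[C@@H]1O[C@H](CO)[C@@H](O)[C@H]1O` carries hydrogen in place of amino on an aromatic carbon and gives 17700 nM in this assay; the step of an at least 1.1-fold lower number from compound 1 to compound 2 (0.05 log units; that floor lies within the scatter) stays within scatter. Compound 3 `C#Cc1cn([C@@H]2O[C@H](CO)[C@@H](O)[C@H]2O)c2nc(N)nc(OC)c12` is not yet measured and differs from compound 1 by ethynyl in place of 1-benzofuran-2-yl on an aromatic carbon. Among the compounds with values here, no measured step covers such a change, so no direction can be drawn from the data. Compound 3 is therefore expected at an estimated 20000 nM with a range of 8000 nM to 50000 nM, a step of a number no higher from compound 1 to compound 3 (the limit leaves the size open) that is expected to stay within the scatter.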

Compound 3, half-maximal inhibitory concentration: > 100000 nM
Compound 3: a limit, no number; the forecaster's own chance of this, stated with the estimate: 55%; at least 5.0-fold (0.69 log units) between middle value and limit.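

Compound 1 and compound 3 each give only a limit in this assay, and no step can be read between the two. The compounds shown leave open how far ethynyl in place of 1-benzofuran-2-yl shifts inhibition, and in which direction.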